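Dichlorophenyl Sulfonamide: Cytotoxicity Expected Near the Ceiling

The source may hold more compounds than are shown below. What is called first, only, known or untested is meant among the compounds shown, and "the series" means these compounds.

Three sulfonamides sharing one core have been tested in an ADME assay on HEK293 cells (Homo sapiens) for cytotoxicity, read by resazurin assay, with a stated time of 48 h; on this read-out lower numbers stand for higher toxicity in this test and higher numbers for lower toxicity in this test. Compound 1 `Cc1cccc(S(=O)(=O)Nc2ccc(-c3nc4ccccc4o3)cc2)c1` reaches only the limit of this assay, giving > 100000 nM. Within the data shown here, compound 2 `CCc1ccc(S(=O)(=O)Nc2ccc(-c3nc4ccccc4o3)cc2)cc1` is the one compound with a numerical reading, giving 82000 nM in this assay. Compound 3 `O=S(=O)(Nc1ccc(-c2nc3ccccc3o2)cc1)c1ccc(F)cc1` also sits at the limit, giving > 100000 nM. Between these three, the steps are small: an at least 1.2-fold lower number from compound 1 to compound 2 (0.08 log units; that floor lies within the scatter), an at least 1.2-fold higher number from compound 2 to compound 3 (0.08 log units; that floor lies within the scatter), and a step that the two limits leave unreadable from compound 1 to compound 3. The picture is shaped by the limit of > 100000 nM in this assay, at which 2 of the 3 values shown sit, so compound 3 stands at the top of what this assay can read.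

Compound 4 `O=S(=O)(Nc1ccc(-c2nc3ccccc3o2)cc1)c1ccc(Cl)c(Cl)c1` differs from compound 3 by 3,4-dichlorophenyl in place of 4-fluorophenyl on a sulfonyl sulfur. Among the measured compounds shown here, no measured step exchanges one halogen pattern for another, so the bearing steps are those above, all within the scatter. He therefore expects no movement beyond the scatter, and compound 4 is estimated at 85000 nM in this assay, in the range 30000 nM to 200000 nM, the expected step being an at least 1.1-fold lower number from compound 3 to compound 4 (0.07 log units; that floor lies within the scatter).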

Compound 4, half-maximal cytotoxic concentration: > 100000 nM
Compound 4: a limit, no number; the forecaster's own chance of this, stated with the estimate: 45%; at least 1.1-fold (0.07 log units) between middle value and limit.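

In this assay compound 4 gives > 100000 nM, which is a limit and not a number. Among these compounds, the one readable new step is an at least 1.2-fold higher number from compound 2 to compound 4 (0.08 log units; that floor lies within the scatter), while the steps to compound 4 from compound 1 and from compound 3 cannot be read, as both ends of each are limits. So a second halogen on the phenyl at the sulfonyl sulfur, here two chlorines in place of one fluorine, brings no reading beyond the scatter, and the ceiling now holds most of the series: the limit of > 100000 nM in this assay, at which 3 of the 4 values shown sit.

Going by these compounds, how far compound 1, compound 3 and compound 4 lie past that limit stays open, and so does any order among them. Also open, on these data alone, is whether an amine or a carboxylic acid on this phenyl, or a longer chain in place of the ethyl of compound 2, would move the reading beyond the scatter.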